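Anilino series: tert-butyl in place of hydrogen

A few compounds are considered here, and "the series" means these few. Any claim that something is new, unique, unknown or untested is made for them only; others in the source may bear on it.

Compound 3 `Oc1nc2nonc2nc1Nc1ccccc1` carries an unsubstituted phenyl on the shared core. In an assay on mitochondria from L6 cells (Rattus norvegicus) for activation, with a stated time of 90 min (on this read-out higher numbers stand for an effect only at larger amounts of compound and lower numbers for an effect already at smaller amounts), compound 3 gives 66700 nM, the highest of the three numbers obtained so far. Compound 1 `Oc1nc2nonc2nc1Nc1ccc(OCC(F)(F)F)cc1` gives 42300 nM in this assay, and compound 2 `Oc1nc2nonc2nc1Nc1cccc(S(F)(F)(F)(F)F)c1` gives 3700 nM. The two steps leading to compound 3 are of very different size: a 1.6-fold higher number from compound 1 to compound 3 (0.20 log units; within the scatter), whereas an 18-fold higher number from compound 2 to compound 3 (1.26 log units; beyond the scatter).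

Compound 4 `CC(C)(C)c1cccc(Nc2nc3nonc3nc2O)c1` is the next point in the series. Change relative to compound 3: tert-butyl in place of hydrogen on an aromatic carbon. The precedent that bears most directly on it is the step from compound 2, in which a group of several heavy atoms on an aromatic carbon of the same ring went together with a far lower number; the trifluoroethoxy case of compound 1 adds little either way. Within the data shown here, no tert-butyl analogue has been measured in this assay, so the size of the effect is uncertain. The expected step is a 7.4-fold lower number from compound 3 to compound 4 (0.87 log units; beyond the scatter), a decrease kept smaller than the measured one because an 18-fold higher number from compound 2 to compound 3 (1.26 log units; beyond the scatter) involved a different group. Compound 4 is accordingly estimated at 9000 nM in this assay, with a range from 2500 nM to 35000 nM.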

Compound 4, half-maximal effective concentration: 2200 nM
The estimate for compound 4 lay 4.1-fold (0.61 log units) above the measured number; measured number below the stated range.
By their numbers in this assay, from the lowest: compounds 4 and 2 (each within the scatter of the next); then compounds 1 and 3 (each within the scatter of the next).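

In this assay, tert-butyl on this aromatic carbon gives a large step, a 30-fold lower number from compound 3 to compound 4 (1.48 log units; beyond the scatter), so a large drop at this carbon does not depend on the fluorine and sulfur atoms of the group in compound 2, since tert-butyl has carbon atoms only. Exchanging that group for tert-butyl gives a 1.7-fold lower number from compound 2 to compound 4 (0.23 log units; within the scatter), which lies within the scatter, so this read-out does not separate the two groups and compounds 2 and 4 stand as equals at this carbon. Nothing available here accounts for the size of the tert-butyl step or for the match between the two groups.

From the compounds shown here alone, whether a smaller carbon group such as methyl, or an amine or a carboxylic acid, on the same carbon would also give a low number remains open, so the link between group size and the number cannot yet be drawn. Compound 1 goes against any rule that a larger group alone lowers the number, as 2,2,2-trifluoroethoxy gives only a 1.6-fold higher number from compound 1 to compound 3 (0.20 log units; within the scatter), and the compounds shown do not tell whether the group or its place on the ring sets this apart.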